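A Chain-Linked Amine in Place of Piperidine

The source may report more compounds than this note shows. Statements on the series, on what has been measured and on what is new or still open speak of the compounds shown alone.

Measured in an assay on HEK293 cells for inhibition of Steryl-sulfatase (Homo sapiens), tested at 0.1 uM; a lower number here means a weaker effect, a higher number a stronger effect of the compound at the concentration tested:
Compound 1 `CCN(Cc1ccccc1)c1cccc(C(=O)N2CCc3ccc(OS(N)(=O)=O)cc3C2)c1`: 17.3%
Compound 2 `CCN(Cc1ccncc1)c1cccc(C(=O)N2CCc3ccc(OS(N)(=O)=O)cc3C2)c1`: 33.3%
Compound 3 `NS(=O)(=O)Oc1ccc2c(c1)CN(C(=O)c1cccc(N3CCCCC3)c1)CC2`: 1%

Compound 3 stands lowest of the three; compound 1 is its nearest neighbour and compound 2 the furthest, both beyond the scatter. The next compound, compound 4 `CN(CCCN1CCCCC1)c1cccc(C(=O)N2CCc3ccc(OS(N)(=O)=O)cc3C2)c1`, differs from compound 3 in one place: methyl(3-(piperidin-1-yl)propyl)amino in place of piperidin-1-yl on an aromatic carbon. Going by the values given here, the steps that bear on this change are those leading into compound 3, namely a number 16.3 percentage points lower from compound 1 to compound 3 (beyond the scatter) and a number 32.3 percentage points lower from compound 2 to compound 3 (beyond the scatter); in each, piperidin-1-yl replaced an acyclic amine bearing an ethyl group and a saturated chain carbon, and the number fell. Compound 4 reverses that direction, again carrying an acyclic amine at the same aromatic carbon, so a modest rise from compound 3 is expected, not a large one. For compound 4 in this assay the expected value is 18%, with a range from 3% to 38%. The estimated step is therefore a number 17 percentage points higher from compound 3 to compound 4 (beyond the scatter).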

Compound 4, a percentage reported as inhibition, at one concentration (the size of the read-out at that concentration, not a potency): 24.1%
Estimate against measurement, compound 4: 6.1 percentage points below; low and high end bracket the measured number.
By their numbers in this assay, from the lowest: compound 3; then compounds 1, 4 and 2 (each within the scatter of the next, the first and the last beyond it).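

In this assay the step from the directly attached piperidin-1-yl to methyl(3-(piperidin-1-yl)propyl)amino is a number 23.1 percentage points higher from compound 3 to compound 4 (beyond the scatter) and shows that the same piperidine ring can stand on this aromatic carbon without the low read-out of compound 3 when a propyl chain and an acyclic amine nitrogen carry it. Compared with the earlier acyclic amines, the new group gives a number 9.2 percentage points lower from compound 2 to compound 4 (within the scatter) and a number 6.8 percentage points higher from compound 1 to compound 4 (within the scatter) so an aromatic ring on the chain is not needed for a read-out in this range. No evidence on the cause of these differences is available.

On these data alone, because the chain, the methyl group and the amine nitrogen enter together, the share of each in the rise remains open. Also open, as far as these compounds go, is how a shorter ethyl chain or a morpholine at the chain end would read.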